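The source may report more compounds than this note shows. Statements on the series, on what has been measured and on what is new or still open speak of the compounds shown alone.

Compound 1 `COC(=O)/C=C/c1cccc(N(Cc2ccc(-c3ccc(OC)cc3)cc2)C(=O)C2CCCCC2)c1` gives 89 nM in an assay on isolated protein with Bile acid receptor (Homo sapiens) as the target; a lower number here means that less compound is needed, a higher number that more compound is needed for the effect.
Compound 2 `COC(=O)/C=C/c1cccc(N(Cc2ccc(-c3ccc(OC)cc3)cc2)C(=O)C(C)C)c1` gives 97 nM in this assay.
Compound 3 `CCOC(=O)/C=C/c1ccc(CN(C(=O)C2CCCCC2)c2cccc(/C=C/C(=O)OC)c2)cc1` gives only a limit in this assay, > 1000 nM.

Among the numbers shown, compound 2 stands next to compound 1, and the two are not separated: a 1.1-fold higher number from compound 1 to compound 2 (0.04 log units; within the scatter). Compound 3 contributes no number, only a limit (the limit of > 1000 nM in this assay, at which 1 of the 3 values shown sits), so compound 2 sits with compound 1 as the pair that can be compared.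

The step followed here leads from compound 2 to compound 4 `COC(=O)/C=C/c1cccc(N(Cc2ccc(/C=C/c3ccccc3)cc2)C(=O)C(C)C)c1`, which has not been measured. The change is 2-phenylethenyl in place of 4-methoxyphenyl on an aromatic carbon.

Among the compounds with values here, one measured step touches the same place: an at least 11-fold higher number from compound 1 to compound 3 (1.05 log units; beyond the scatter). In that step the 4-methoxyphenyl gave way to a chain without any aromatic ring, and the value became a limit. In compound 4 the entering group still carries a six-membered aromatic ring of carbon only, with one double bond outside aromatic rings and no hydrogen-bond acceptor. A loss in this assay is therefore expected, but a smaller one than the step from compound 1 to compound 3, as compound 4 keeps a ring. Compound 4 is estimated at 350 nM, with a range from 100 nM to 1500 nM, meaning an expected step of a 3.6-fold higher number from compound 2 to compound 4 (0.56 log units; beyond the scatter).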

Compound 4, half-maximal effective concentration: 65 nM
Compound 4: the middle estimate sits 5.4-fold (0.73 log units) above what was measured; the whole stated range lies above it.
By their numbers in this assay, from the lowest: compounds 4, 1 and 2 (each within the scatter of the next). At a limit, above all of these: compound 3.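

Replacing the 4-methoxyphenyl with 2-phenylethenyl on this aromatic carbon gives two values in this assay that cannot be told apart: a 1.5-fold lower number from compound 2 to compound 4 (0.17 log units; within the scatter). This position therefore accepts a group with a double bond outside the aromatic rings, and on this isopropyl amide the value holds without the hydrogen-bond acceptor of the 4-methoxyphenyl. Before this result, the only change seen at this place was the one in compound 3, whose 2-(ethoxycarbonyl)ethenyl group gave a limit of the assay rather than a number: the limit of > 1000 nM in this assay, at which 1 of the 4 values shown sits.

The compounds shown leave open whether 2-phenylethenyl behaves the same way on the cyclohexyl amide of compound 1, as it appears here only with isopropyl on the carbonyl carbon. Also open, going by these compounds, is how this position responds to an amine or a carboxylic acid on the aromatic ring of the entering group, or to a saturated two-carbon chain in place of the double bond.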